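From 4-chlorophenyl to 2,4-dichlorophenyl in compound 3

The compounds below may be only part of what the source reports. "The series", "measured", "known", "first", "only" and "open" are said of these compounds alone.

Compound 1 `COc1cccc(CNC(=O)c2c([N+](=O)[O-])noc2-c2ccc(Cl)cc2)c1` gives 68600 nM in an ADME assay on J774.A1 cells (Mus musculus) for cytotoxicity, read by MTT assay, with a stated time of 48 h (on this read-out higher numbers stand for lower toxicity in this test and lower numbers for higher toxicity in this test), while compound 2 `COc1ccc(CNC(=O)c2c([N+](=O)[O-])noc2-c2ccc(Cl)cc2)cc1OC` gives 106000 nM there. These two numbers are all that is known so far. They lie within the scatter of each other, so compound 2 cannot be ranked against compound 1. Compound 3 `COc1ccc(CNC(=O)c2c([N+](=O)[O-])noc2-c2ccc(Cl)cc2Cl)cc1OC` departs from compound 2 in one place: chloro in place of hydrogen on an aromatic carbon and this turns 4-chlorophenyl into 2,4-dichlorophenyl, with the new chloro in place of hydrogen on an aromatic carbon, ortho to a large group and meta to a chloro group. Going by the values given here, the one measured step is a 1.5-fold higher number from compound 1 to compound 2 (0.19 log units; within the scatter) and it stays within the scatter. It is a different substitution, methoxy in place of hydrogen, so it offers only a loose guide. Among the compounds with values here, no measured compound carries this added chloro, so no shift beyond the scatter is expected in this assay for this change. The expected step is a 1.3-fold lower number from compound 2 to compound 3 (0.12 log units; within the scatter) in this estimate. For compound 3 the estimated value is 80000 nM with an expected range from 35000 nM to 160000 nM for that number.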

Compound 3, half-maximal cytotoxic concentration: 81800 nM
Compound 3: middle estimate off by 1.0-fold (0.01 log units), on the low side, and the stated range covers the measured number.
By their numbers in this assay, from the lowest: compounds 1, 3 and 2 (each within the scatter of the next).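

In this assay, adding the chloro that turns 4-chlorophenyl into 2,4-dichlorophenyl gives a 1.3-fold lower number from compound 2 to compound 3 (0.11 log units; within the scatter), so this change cannot be told apart from repeat measurement. Going by these compounds alone, this is the first look at a change on the chlorophenyl part of the molecule, since the only earlier step, methoxy in place of hydrogen, lay elsewhere, and it shows that an aromatic carbon ortho to a large group and meta to a chloro group can carry a chloro with no shift that can be read in this test. No measurement of any other property of these compounds bears on this result.

The compounds shown leave open whether this tolerance belongs to the position or to the chloro alone, as a single small substituent has been seen there and nothing shows how an amine, a carboxylic acid or a longer alkyl chain at the same carbon would read. They also leave open whether replacing the 4-chloro group itself, for instance with a methoxy or a trifluoromethyl group, would move the number beyond the scatter.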